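Replacing dichlorophenyl with cyanophenyl on the sulfonyl of compound 3

A few compounds are considered here, and "the series" means these few. Any claim that something is new, unique, unknown or untested is made for them only; others in the source may bear on it.

The measured compounds:
compound 1, `COc1ccc2ncc(S(=O)(=O)c3ccc(Cl)c(Cl)c3)c(N3CCC(C)CC3)c2c1`, giving 87%
compound 2, `COc1ccc(S(=O)(=O)c2cnc3ccc(F)cc3c2N2CCC(C)CC2)cc1`, giving 85%
compound 3, `CC1CCN(c2c(S(=O)(=O)c3ccc(Cl)c(Cl)c3)cnc3ccc(F)cc23)CC1`, giving 91%

All three were run in an assay on isolated protein for displacement of a labelled ligand from metabotropic glutamate receptor 5 (Homo sapiens), with a stated time of 60 min, tested at 1 uM; on this read-out higher numbers stand for more inhibition at the one concentration tested (going by the name of the read-out) and lower numbers for less inhibition. Compound 3 carries the largest of the three numbers, yet neither gap reaches beyond the scatter: the step of a number 4 percentage points higher from compound 1 to compound 3 (within the scatter) is small, and so is the step of a number 6 percentage points higher from compound 2 to compound 3 (within the scatter). On these numbers the three compounds cannot be told apart.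

Compound 4, `CC1CCN(c2c(S(=O)(=O)c3ccc(C#N)cc3)cnc3ccc(F)cc23)CC1`, has not been measured. It differs from compound 3 by 4-cyanophenyl in place of 3,4-dichlorophenyl on a sulfonyl sulfur. Within the data shown here, the one measured step that bears on this place is the exchange of aryl groups on the sulfonyl sulfur, a number 6 percentage points higher from compound 2 to compound 3 (within the scatter), which stayed within the scatter. Among the measured compounds shown here, no measured step involves a 4-cyanophenyl group, so that part of the change is untested. Because a number 6 percentage points higher from compound 2 to compound 3 (within the scatter) was within the scatter, the step of a number 9 percentage points lower from compound 3 to compound 4 (within the scatter) is expected to be small as well, with a little room for a drop. The estimate for compound 4 is 82%, with a range from 60% to 95%.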

Compound 4, a percentage reported as inhibition, at one concentration (the size of the read-out at that concentration, not a potency): 75%
For compound 4 the middle estimate is 7 percentage points above the measured one; the measured number falls inside the stated range.
By their numbers in this assay, from the lowest: compounds 4, 2, 1 and 3 (each within the scatter of the next, the first and the last beyond it).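

At the sulfonyl sulfur, the aryl group can matter in this assay: a number 16 percentage points lower from compound 3 to compound 4 (beyond the scatter) is the first step among these compounds to pass beyond the scatter, whereas a number 6 percentage points higher from compound 2 to compound 3 (within the scatter) did not. The 4-cyanophenyl group is therefore not interchangeable with 3,4-dichlorophenyl at this place, although a number 10 percentage points lower from compound 2 to compound 4 (within the scatter) leaves it indistinguishable from 4-methoxyphenyl. Nothing available explains the difference between the 3,4-dichlorophenyl and 4-cyanophenyl compounds.

The compounds shown leave open whether the fall follows the departure of the two chlorines or the arrival of the nitrile, which a phenyl group carrying a single chlorine could help separate. They also leave open how an amine or a carboxylic acid in place of the nitrile would read out at this place.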